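From Fluoro to Methoxy on the Amide Phenyl Ring

This account rests on a few compounds, and the source may have more. Where it says the series, first, only, none or still open, it means among the compounds named here.

Of the compounds shown here, three have been tested in a functional assay on NPC-TW01 cells (Homo sapiens) for antiproliferative activity, read by MTT assay, with a stated time of 72 h; a lower number here means a stronger inhibitor of growth, a higher number a weaker inhibitor of growth.
Compound 1 `O=C(COc1c(-c2ccccc2)oc2ccccc2c1=O)Nc1ccc2ccccc2c1` gives 6520 nM.
Compound 2 `O=C(COc1ccc2oc(-c3ccccc3)cc(=O)c2c1)Nc1ccc2ccccc2c1` gives 6750 nM.
Compound 3 `O=C(COc1ccc2oc(-c3ccccc3)cc(=O)c2c1)Nc1ccc(F)cc1` gives 740 nM.

Compound 3 has the lowest number of the three, and its gaps to compound 1 and to compound 2 both lie beyond the scatter. Compound 4 `COc1ccc(NC(=O)COc2ccc3oc(-c4ccccc4)cc(=O)c3c2)cc1` differs from compound 3 in one place: methoxy in place of fluoro on an aromatic carbon. Among the compounds with values here, the only measured single change, a 9.1-fold lower number from compound 2 to compound 3 (0.96 log units; beyond the scatter), exchanges the whole group on the amide nitrogen and tells nothing about a methoxy in place of a fluoro. Within the data shown here, no measured step bears directly on this change. The step of a 1.2-fold higher number from compound 3 to compound 4 (0.09 log units; within the scatter) is therefore expected to stay within the scatter. Compound 4 is estimated at 900 nM, with a range from 350 nM to 2500 nM.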

Compound 4, concentration for 50% growth inhibition: 710 nM
Estimate against measurement, compound 4: 1.3-fold (0.10 log units) above; measured number inside the range.
By their numbers in this assay, from the lowest: compounds 4 and 3 (each within the scatter of the next); then compounds 1 and 2 (each within the scatter of the next).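

In this assay, putting methoxy in place of fluoro gives a 1.0-fold lower number from compound 3 to compound 4 (0.02 log units; within the scatter) and so makes no measurable difference, even though methoxy brings a hydrogen-bond acceptor that fluoro lacks. Putting 4-methoxyphenyl in place of naphthalen-2-yl gives a 9.5-fold lower number from compound 2 to compound 4 (0.98 log units; beyond the scatter) and shows that the gain over naphthalen-2-yl is not unique to 4-fluorophenyl. Nothing available explains why the two groups read alike. Still open, on these data alone, is whether an amine or a carboxylic acid at this position would keep the number in this range. Also open, as far as these compounds go, is whether 4-methoxyphenyl would bring a similar gain on the core of compound 1.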